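The source may hold more compounds than are shown below. What is called first, only, known or untested is meant among the compounds shown, and "the series" means these compounds.

Within the data shown here, in a functional assay on U-937 cells (Homo sapiens) for inhibition, read by MTT assay, with a stated time of 72 h (a lower number here means a stronger inhibitor, a higher number a weaker inhibitor), compound 2 `Nc1ccccc1NC(=O)c1ccc(CNCc2nc(-c3ccc(F)cc3)no2)cc1` gives 1250 nM, the higher of the two numbers so far, while compound 1 `Nc1ccccc1NC(=O)c1ccc(CNCc2nc(-c3ccc(Cl)cc3)no2)cc1` gives 430 nM. Compound 3 `Nc1ccccc1NC(=O)c1ccc(CNCc2nc(-c3cccs3)no2)cc1` is still unmeasured and differs from compound 2 as follows: thiophen-2-yl in place of 4-fluorophenyl on an aromatic carbon. Among the measured compounds shown here, the only measured step bearing on this is a 2.9-fold higher number from compound 1 to compound 2 (0.46 log units; beyond the scatter), with fluoro in place of chloro on an aromatic carbon. That modest step is a loose guide, as the whole aromatic ring is exchanged here and the data give no direction. In this assay, a step of no more than similar size is expected. The estimated change is a 1.3-fold lower number from compound 2 to compound 3 (0.10 log units; within the scatter). For compound 3 the expected value is 1000 nM, within an estimated range of 350 nM to 2800 nM.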

Compound 3, half-maximal inhibitory concentration: 5960 nM
Estimate against measurement, compound 3: 6.0-fold (0.78 log units) below; the whole stated range lies below it.
By their numbers in this assay, from the lowest: compound 1; then compound 2; then compound 3.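

In this assay, this position responds to exchanging the whole aromatic ring, not only the halogen on it: thiophen-2-yl in place of 4-fluorophenyl gives a clear loss (a 4.8-fold higher number from compound 2 to compound 3 (0.68 log units; beyond the scatter)), and in place of 4-chlorophenyl a larger one (a 14-fold higher number from compound 1 to compound 3 (1.14 log units; beyond the scatter)). Of the three compounds, the thiophene is the weakest inhibitor, so here this smaller ring does not stand in for either halogen-bearing phenyl ring. Nothing shown bears on the cause. Still open, as far as these compounds go, is how plain phenyl, with no halogen, or a pyridine ring would compare at this position.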